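The source may hold more compounds than are shown below. What is called first, only, known or untested is meant among the compounds shown, and "the series" means these compounds.

In a functional assay on BEAS-2B cells (Homo sapiens) for inhibition, read by MTT assay, with a stated time of 72 h (a lower number here means a stronger inhibitor, a higher number a weaker inhibitor), compound 1 `C=C(c1ccc(Cl)c(Cl)c1)C1COC2(CCCCC2)OO1` gives a measured value of 39400 nM. Compound 2 `C=C(c1cc(Cl)cc(Cl)c1OCc1ccccc1)C1COC2(CCCCC2)OO1` is reported only as a limit, > 100000 nM. Compound 3 `C=C(c1ccc(F)c(F)c1)C1COC(C)(C)OO1` is also reported only as a limit, > 100000 nM, so it has no exact place on the scale. Compound 3 thus belongs to the limit of > 100000 nM in this assay, at which 2 of the 3 values shown sit.

Compound 4 `C=C(c1ccc(OC)c(F)c1)C1COC(C)(C)OO1` carries methoxy in place of fluoro on an aromatic carbon. The methoxy stands ortho to a fluoro group and para to a large group. For the measured compounds named here, no measured pair in this set isolates such a change, so the step can be judged only loosely. A small step in this assay is expected, with no firm direction, and the reading will probably stay close to the limit. Compound 1, at 39400 nM, shows that a number can appear in this set, so a measurable result is not ruled out. The estimated change is an at least 1.1-fold lower number from compound 3 to compound 4 (0.04 log units; that floor lies within the scatter). Compound 4 is estimated at 90000 nM, with an expected range of 40000 nM to 200000 nM.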

Compound 4, half-maximal inhibitory concentration: 68700 nM
Estimate against measurement, compound 4: 1.3-fold (0.12 log units) above; measured number inside the range.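

Putting methoxy in place of fluoro on this aromatic carbon, para to a large group and ortho to a fluoro group, gives in this assay a step of an at least 1.4-fold lower number from compound 3 to compound 4 (0.16 log units; that floor lies within the scatter). For the compounds shown here, this gives the first exact number for the core of compound 3, and it shows that this single change on the aromatic ring is enough to bring a compound with that core onto the measurable scale. The step is only a floor, and the true size of the change stays unknown, as compound 3 remains a limit: the limit of > 100000 nM in this assay, at which 2 of the 4 values shown sit.

Going by these compounds, whether a hydroxy group, an amine or a longer alkoxy chain on this carbon would shift the number further remains open. Also open, on these data alone, is whether methoxy would have a similar effect on the core of compound 1, which differs from compound 4 in more than one place.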